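This account rests on a few compounds, and the source may have more. Where it says the series, first, only, none or still open, it means among the compounds named here.

Measured so far in a functional assay on HCT-116 cells (Homo sapiens) for cytotoxicity; a higher number here means a weaker inhibitor, a lower number a stronger inhibitor:
- Compound 1 `COc1cc(N2CCC(CC(=O)N3CCN(C)CC3)CC2)ccc1Nc1nc(NC2CCCCC2)c2nc[nH]c2n1`: 51 nM
- Compound 2 `CCN(CC)CC1CCN(c2ccc(Nc3nc(NC4CCCCC4)c4nc[nH]c4n3)c(OC)c2)CC1`: 74 nM

Compound 2, at 74 nM, cannot be told apart from compound 1, since the two lie within the usual scatter of repeated measurements. Still unmeasured is compound 3 `COc1cc(N2CCC(C(=O)N3CC(O)C3)CC2)ccc1Nc1nc(NC2CCCCC2)c2nc[nH]c2n1`, which has (3-hydroxyazetidin-1-yl)carbonyl in place of (diethylamino)methyl on a saturated ring carbon.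

Within the data shown here, only one measured step bears on this change: a 1.5-fold higher number from compound 1 to compound 2 (0.16 log units; within the scatter). There, diethylamino took the place of (4-methylpiperazin-1-yl)carbonyl on a saturated chain carbon, and this assay showed no change beyond the scatter. This is thin evidence. Neither measured compound carries the four-membered ring of compound 3, and the change here sits on a ring carbon rather than a chain carbon. A large step is therefore not expected, though the direction is uncertain, with only a slight lean towards a higher number. The estimate amounts to an expected 1.6-fold higher number from compound 2 to compound 3 (0.21 log units; within the scatter). For compound 3, the expected value is 120 nM, with an estimated range from 40 nM to 350 nM.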

Compound 3, half-maximal inhibitory concentration: 50 nM
For compound 3 the middle estimate is 2.4-fold (0.38 log units) above the measured one, and the stated range covers the measured number.
By their numbers in this assay, from the lowest: compounds 3, 1 and 2 (each within the scatter of the next).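

On the saturated ring carbon three ring bonds from the ring nitrogen, in this assay, (3-hydroxyazetidin-1-yl)carbonyl in place of (diethylamino)methyl gives a 1.5-fold lower number from compound 2 to compound 3 (0.17 log units; within the scatter) and so does not separate the two compounds. The same group in place of ((4-methylpiperazin-1-yl)carbonyl)methyl gives a 1.0-fold lower number from compound 1 to compound 3 (0.01 log units; within the scatter) and again no separation. This position has therefore now carried three different groups with no step beyond the scatter, including a group with a four-membered ring and a hydrogen-bond donor, which neither earlier group has, and a carbonyl attached directly to the ring carbon. No further data here explain why the three numbers sit so close together.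

As far as these compounds go, it remains open whether a carboxylic acid, a primary amine or a longer carbon chain on this same ring carbon would move the number beyond the scatter. All three compounds also share the rest of their structure, so they cannot show how this assay responds to changes elsewhere in the shared core.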